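The source may report more compounds than this note shows. Statements on the series, on what has been measured and on what is new or still open speak of the compounds shown alone.

Among the measured compounds shown here, compound 2 `O=S(=O)(NCCCNCc1ccc(Cl)c(Cl)c1)c1cc(C(F)(F)F)cc(C(F)(F)F)c1` gives the lower of the two numbers measured so far in a functional assay on PANC-1 cells (Homo sapiens) for inhibition, read by MTT assay, with a stated time of 72 h (a lower number here means a stronger inhibitor of growth, a higher number a weaker inhibitor of growth), namely 5600 nM, while compound 1 `O=S(=O)(NCCCNCc1ccccc1Cl)c1cc(C(F)(F)F)cc(C(F)(F)F)c1` gives 15000 nM. For the measured compounds named here, the one measured step, a 2.7-fold lower number from compound 1 to compound 2 (0.43 log units; beyond the scatter), bears directly on the next change. Compound 3 `CN(CCCNS(=O)(=O)c1cc(C(F)(F)F)cc(C(F)(F)F)c1)Cc1ccccc1` differs from compound 2 by benzyl(methyl)amino in place of (3,4-dichlorobenzyl)amino on a saturated chain carbon, three bonds along the chain from a sulfonamide nitrogen. Since adding chlorine atoms to that ring lowered the number beyond the scatter, removing both is expected to raise it by a similar modest amount. Compound 3 is therefore estimated at 12000 nM, in a range from 5000 nM to 30000 nM, a step of a 2.1-fold higher number from compound 2 to compound 3 (0.33 log units; beyond the scatter).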

Compound 3, concentration for 50% growth inhibition: > 50000 nM
Compound 3: no number, only a limit; the forecaster's own chance of this, stated with the estimate: 15%; at least 4.1-fold (0.61 log units) between middle value and limit.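

The reading for compound 3 is a limit of the assay, not a number: the limit of > 50000 nM in this assay, at which 1 of the 3 values shown sits. Even so, benzyl(methyl)amino gives an at least 8.9-fold higher number from compound 2 to compound 3 (0.95 log units; beyond the scatter), and an at least 3.3-fold higher number from compound 1 to compound 3 (0.52 log units; beyond the scatter), so this position tolerates the change poorly against either chlorinated group. The entering group has no chlorine and no hydrogen-bond donor, unlike the group it replaces in compound 2.

The compounds shown cannot separate losing the chlorines from adding the methyl. A plain benzylamino group or a (3,4-dichlorobenzyl)(methyl)amino group would pull those two apart.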